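The source may report more compounds than this note shows. Statements on the series, on what has been measured and on what is new or still open speak of the compounds shown alone.

Three measured compounds share one core and differ in the sugar portion attached to it. In a functional assay on ACHN cells (Homo sapiens) for inhibition, in the presence of a further agent that is not named here (on this read-out lower numbers stand for stronger inhibition and higher numbers for weaker inhibition), compound 1 `COc1ccc(-c2cc(=O)c3c(O)c(OC)c(O[C@@H]4O[C@H](CO[C@@H]5O[C@@H](C)[C@H](O)[C@@H](OC(C)=O)[C@H]5O)[C@@H](O)[C@H](O)[C@H]4O)cc3o2)cc1` gives 25200 nM. Compound 2 `COc1ccc(-c2cc(=O)c3c(O)c(OC)c(O[C@@H]4OC(CO[C@@H]5OC(C)[C@H](O)[C@H](O)C5OC(C)=O)[C@@H](O)[C@H](O)C4O)cc3o2)cc1` gives 13700 nM in this assay, and compound 3 `COC1=C(O)C2=C(O)C=C(c3ccc(OC)cc3)OC2=CC1OC1OC(O)C(O)C(O)C1O` gives 16500 nM there. Compound 1 carries the highest of these three numbers, yet its gaps to compound 3 and to compound 2 both lie within the usual scatter of repeated measurements, so the three cannot be ranked against one another on this evidence.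

Compound 4 `COc1ccc(-c2cc(=O)c3c(O)c(OC)c(O[C@@H]4OC(CO[C@@H]5OC(C)[C@H](O)[C@H](OC(C)=O)C5O)[C@@H](O)[C@H](O)C4O)cc3o2)cc1` has not yet been measured. Against compound 1 it differs in this way: the two compounds have the same atoms and bonds; at least one stereo element is drawn with a configuration in one of them and without one in the other: 5 of 10 stereo elements differ; a stereocentre at a saturated ring carbon is drawn R in compound 1 and without a configuration in compound 4; a stereocentre at a saturated ring carbon is drawn S in compound 1 and without a configuration in compound 4; a stereocentre at a saturated ring carbon is drawn R in compound 1 and S in compound 4; a stereocentre at a saturated ring carbon is drawn R in compound 1 and without a configuration in compound 4 Nothing leaves and nothing enters; the atoms and bonds are the same, and what differs is how several stereocentres at saturated ring carbons are drawn. For the measured compounds named here, no step between measured compounds is available to guide the expectation, and a change confined to drawn stereochemistry gives no ground to expect a shift beyond the scatter. The expected step is therefore a 1.0-fold lower number from compound 1 to compound 4 (0.00 log units; within the scatter). Compound 4 is estimated to give about 25000 nM in this assay, with a likely range from 12000 nM to 50000 nM.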

Compound 4, half-maximal inhibitory concentration: 16900 nM
Compound 4: middle estimate off by 1.5-fold (0.17 log units), on the high side; low and high end bracket the measured number.
By their numbers in this assay, from the lowest: compounds 2, 3, 4 and 1 (each within the scatter of the next).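

For the compounds shown here, compound 1 and compound 4 form the first pair here with the same atoms and bonds, so this is the first direct look at what redrawing stereocentres in the sugar portion does. In this assay, that change comes with a 1.5-fold lower number from compound 1 to compound 4 (0.17 log units; within the scatter), so the pair gives no sign that these stereocentres matter for the read-out. Even this reading is limited, and the pair cannot be taken as a clean comparison of two defined stereoisomers, because of one feature of how they are drawn: the fact that one of compounds 1 and 4 is drawn with a defined configuration and the other without, at the place where they differ

From the compounds shown here alone, whether a fully defined partner of compound 1, with every stereocentre drawn, would differ beyond the scatter remains open. So does whether placing an amine or a carboxylic acid on the sugar portion would shift the number beyond the scatter.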